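A Smaller Swap on the Same Amide-Type Nitrogen

The compounds below may be only part of what the source reports. "The series", "measured", "known", "first", "only" and "open" are said of these compounds alone.

In a functional assay on MCF7 cells (Homo sapiens) for antiproliferative activity, read by MTT assay, with a stated time of 48 h (on this read-out lower numbers stand for stronger inhibition and higher numbers for weaker inhibition), compound 1 `CCn1c(C(=O)Nc2cccc(C(F)(F)F)c2)ccc1C(CC)(CC)c1ccc(OCCC(O)(CC)CC)c(C)c1` gives > 50000 nM, which is a limit and not a number. For the measured compounds named here, compound 2 `CCOC(=O)C(CC(=O)OC)NC(=O)c1ccc(C(CC)(CC)c2ccc(OCCC(O)(CC)CC)c(C)c2)n1CC` gives 390 nM, the only true number so far. Going by the values given here, the one measured step, an at least 120-fold lower number from compound 1 to compound 2 (2.10 log units; beyond the scatter), is large and shows that the group on this nitrogen can matter. Compound 3 `CCn1c(C(=O)NC(CC(=O)O)C(=O)OC)ccc1C(CC)(CC)c1ccc(OCCC(O)(CC)CC)c(C)c1` differs from compound 2 by a group of 9 heavy atoms (5 carbon, 4 oxygen; no ring) in place of a group of 11 heavy atoms (7 carbon, 4 oxygen; no ring), on an amide-type nitrogen. Neither group holds a ring, so that step is only a loose guide. A moderate loss of activity is expected, a 3.8-fold higher number from compound 2 to compound 3 (0.59 log units; beyond the scatter). The estimated value for compound 3 is 1500 nM, with an expected range of 300 nM to 15000 nM.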

Compound 3, half-maximal inhibitory concentration: 10200 nM
Estimate against measurement, compound 3: 6.8-fold (0.83 log units) below; the range from low to high includes it.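

Two ring-free groups on this amide-type nitrogen need not behave alike: with a group of 9 heavy atoms in place of a group of 11 heavy atoms, there is a 26-fold higher number from compound 2 to compound 3 (1.42 log units; beyond the scatter). The entering group, with 1 hydrogen-bond donor where the leaving group has 0, still does better than the ring-bearing group of compound 1, with an at least 4.9-fold lower number from compound 1 to compound 3 (0.69 log units; beyond the scatter). As far as these compounds go, that step starts from a limit and not a number, so its full size stays unknown: the limit of > 50000 nM in this assay, at which 1 of the 3 values shown sits.

The compounds shown cannot tell which part of the changed group accounts for the difference. From the compounds shown here alone, how a simple amine or a longer carbon chain on this nitrogen would behave remains open.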